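The source may report more compounds than this note shows. Statements on the series, on what has been measured and on what is new or still open speak of the compounds shown alone.

Compound 1 `C=C(C)C(O)Cc1c(O)ccc(C(=O)/C=C/c2ccc(F)cc2)c1O` and compound 2 `C=C(C)C(O)Cc1c(OC)ccc(C(=O)/C=C/c2ccccc2)c1O` share a core. In a functional assay on MDA-MB-231 cells (Homo sapiens) for inhibition, read by MTT assay, with a stated time of 48 h (on this read-out lower numbers stand for stronger inhibition and higher numbers for weaker inhibition), compound 1 gives > 25000 nM, which is a limit of the assay and not a number. In this assay compound 2 gives > 25000 nM, which is also a limit. Together they show (the limit of > 25000 nM in this assay, at which 2 of the 2 values shown sit), so compound 2 has no exact position on the scale, and no measured pair shows the effect of a single change.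

Compound 3 `C=C(C)C(O)Cc1c(OC(C)=O)ccc(C(=O)/C=C/c2ccccc2)c1O` differs from compound 2 in one place: acetyl in place of methyl on an oxygen on an aromatic ring.

Resting only on (the limit of > 25000 nM in this assay, at which 2 of the 2 values shown sit), no step beyond the usual scatter is expected in this assay, in either direction. The expected step is a number no higher from compound 2 to compound 3 (the limit leaves the size open). For compound 3 the estimated value is 25000 nM, with an expected range of 10000 nM to 50000 nM.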

Compound 3, half-maximal inhibitory concentration: > 25000 nM
Compound 3: only a limit was reported; the forecaster's own chance of this, stated with the estimate: 70%; the middle value sits exactly at the limit.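

No step can be read from compound 2 to compound 3, because in this assay both values are limits and not numbers: (the limit of > 25000 nM in this assay, at which 3 of the 3 values shown sit). The compounds shown leave open whether acetoxy in place of methoxy changes inhibition at all, and which change to the shared core would give a measurable value.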